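Swapping Methoxy for Bromo on a Nitro Compound

The source may hold more compounds than are shown below. What is called first, only, known or untested is meant among the compounds shown, and "the series" means these compounds.

Compound 1 `COc1cc(OC)c(/C=C/S(=O)(=O)Cc2ccc(OC)c([N+](=O)[O-])c2)c(OC)c1`: 2500 nM
Compound 2 `COc1cc(OC)c(/C=C/S(=O)(=O)Cc2ccc(OC)c(N)c2)c(OC)c1`: 2.5 nM

In a functional assay on K562 cells (Homo sapiens) for cytotoxicity, read by trypan blue exclusion, with a stated time of 96 h (a higher number here means a weaker inhibitor, a lower number a stronger inhibitor), compound 1 has the higher of the two numbers, 2500 nM. Compound 3 `COc1cc(OC)c(/C=C/S(=O)(=O)Cc2ccc(Br)c([N+](=O)[O-])c2)c(OC)c1` differs from it by bromo in place of methoxy on an aromatic carbon. Going by the values given here, the only measured step, a 1000-fold lower number from compound 1 to compound 2 (3.00 log units; beyond the scatter), is large, but it replaces the nitro group, which compound 3 keeps. Among the compounds with values here, no measured step covers the methoxy swap, so it bears only loosely. The step expected in this assay is a 1.7-fold lower number from compound 1 to compound 3 (0.22 log units; within the scatter), which means none beyond the scatter in either direction. Compound 3 is estimated at 1500 nM, with an expected range from 300 nM to 7500 nM.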

Compound 3, half-maximal inhibitory concentration: 25000 nM
Beside the measured number, compound 3's estimate is 17-fold (1.22 log units) below it; the whole stated range lies below it.
By their numbers in this assay, from the lowest: compound 2; then compound 1; then compound 3.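

At this position, ortho to a nitro group, bromo in place of methoxy gives a 10-fold higher number from compound 1 to compound 3 (1.00 log units; beyond the scatter) in this assay. Until now only the nitro group had been seen to move the number, so this shows that a second place on the molecule also matters, although the step is far smaller than a 1000-fold lower number from compound 1 to compound 2 (3.00 log units; beyond the scatter) in the same assay. No measured evidence here explains the loss of potency.

The compounds shown leave open whether bromo would cost as much with the amino group of compound 2 in place of nitro. They also leave open how a hydroxyl, chloro or ethoxy group would fare at this position.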